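A few compounds are considered here, and "the series" means these few. Any claim that something is new, unique, unknown or untested is made for them only; others in the source may bear on it.

Measured compounds:
compound 1, `CC(C)(C)c1cc(/C=C/C(=O)NC2CCN(Cc3ccccc3)CC2)cc(C(C)(C)C)c1O` — 33500 nM
compound 2, `Cc1ccccc1CN1CCC(CCNC(=O)/C=C/c2cc(C(C)(C)C)c(O)c(C(C)(C)C)c2)CC1` — 7200 nM

Both compounds were tested in an assay on isolated protein for inhibition of Amine oxidase [flavin-containing] B (Homo sapiens), read by fluorescence, with stated times of 15 min and 20 min; on this read-out lower numbers stand for stronger inhibition and higher numbers for weaker inhibition. Compound 1 gives 33500 nM in this assay, and compound 2 gives 7200 nM. Of the two numbers, compound 2 has the lower one, and the gap to compound 1 lies beyond the usual scatter of repeated measurements. The two compounds differ in more than one place, so their comparison says only that much.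

Compound 3, `CC(C)(C)c1cc(/C=C/C(=O)NCCC2CCN(Cc3ccc(F)cc3)CC2)cc(C(C)(C)C)c1O`, has not yet been measured. It differs from compound 2 in one place: 4-fluorophenyl in place of 2-methylphenyl on a saturated chain carbon bound to an amine nitrogen in a ring. Going by the values given here, no single-change pair among the measured compounds shows what such a swap on the benzyl group does, so there is no measured step to lean on. The expectation is therefore cautious: a step from compound 2 to compound 3 of about a 1.3-fold higher number from compound 2 to compound 3 (0.10 log units; within the scatter), which is within the scatter and carries no clear direction. On that basis compound 3 is estimated at 9000 nM in this assay, within a range from 3000 nM to 30000 nM.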

Compound 3, half-maximal inhibitory concentration: 11100 nM
Beside the measured number, compound 3's estimate is 1.2-fold (0.09 log units) below it, and the stated range covers the measured number.
By their numbers in this assay, from the lowest: compounds 2 and 3 (each within the scatter of the next); then compound 1.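

Going by these compounds alone, the swap of 2-methylphenyl for 4-fluorophenyl, on a saturated chain carbon bound to an amine nitrogen in a ring, gives in this assay a 1.5-fold higher number from compound 2 to compound 3 (0.19 log units; within the scatter), and this is the first comparison here in which only this part of the molecule changes. Within this pair, then, a methyl group on the benzyl ring can give way to a fluorine placed elsewhere on that ring without a difference that this measurement can separate from ordinary repeat-to-repeat variation. No separate measurement is available to explain why these two groups read alike.

This single pair changes two things at once, removing the methyl group and adding the fluorine at another ring position, so it cannot show what either change does alone. It also leaves open what a plain benzyl group, a 4-methoxybenzyl group, or a longer chain between the ring nitrogen and the phenyl ring would do at this position, and whether any of these would move the number beyond the usual scatter.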